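Formyl in place of methyl: expectation for compound 4

The source may hold more compounds than are shown below. What is called first, only, known or untested is meant among the compounds shown, and "the series" means these compounds.

Measured so far:
compound 1, `Cc1ccccc1-c1n[nH]c(-c2ccccc2)n1`, 10 mg/kg
compound 2, `COc1cccc(-c2n[nH]c(-c3ccccc3C)n2)c1`, 5 mg/kg
compound 3, `CCc1ccccc1-c1n[nH]c(-c2cccc(OC)c2)n1`, 4 mg/kg

All three numbers come from a functional assay on the whole organism (Cricetulus griseus) with Cricetinae gen. sp. as the target; on this read-out lower numbers stand for an effect already at smaller amounts and higher numbers for an effect only at larger amounts of compound. In this assay compound 1 gives 10 mg/kg, compound 2 gives 5 mg/kg and compound 3 gives 4 mg/kg. Compound 2 sits with its number between the other two, but its gap to compound 3 and its gap to compound 1 both fall within the usual scatter, so the three measured compounds cannot be told apart on this read-out; no ordering among them is claimed.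

Compound 4, `COc1cccc(-c2n[nH]c(-c3ccccc3C=O)n2)c1`, is not yet measured. It differs from compound 2 in one place: formyl in place of methyl on an aromatic carbon. Among the compounds with values here, no pair of measured compounds shows this change, so there is no measured step to lean on; the only guide is that the three measured compounds, which differ among themselves at two places on the aromatic rings, all land within the scatter of one another.

On that basis a step from compound 2 to compound 4 of no more than the scatter, in either direction, is expected: no change at the digits printed from compound 2 to compound 4 (within the scatter). For compound 4 in this assay the estimated value is 5 mg/kg, with a range from 2 mg/kg to 13 mg/kg.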

Compound 4, dose for half-maximal effect: 10 mg/kg
Estimate against measurement, compound 4: 2.0-fold (0.30 log units) below; the measured number falls inside the stated range.
By their numbers in this assay, from the lowest: compounds 3, 2, 1 and 4 (each within the scatter of the next, the first and the last beyond it).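

In this assay, formyl in place of methyl on an aromatic carbon, ortho to a large group, gives a 2.0-fold higher number from compound 2 to compound 4 (0.30 log units; within the scatter). Within the data shown here, this is the first one-place step, and it shows that at this position compound 2 and compound 4 cannot be told apart on this read-out, even though formyl has one more heavy atom than methyl and, unlike methyl, counts as a hydrogen-bond acceptor. No measurement is available that could account for this result.

Among these compounds, still open is whether this position stays as undemanding with an amine, a carboxylic acid or a longer chain such as propyl, since methyl and formyl are the only two groups compared here in a single step. Also open, going by these compounds, is whether formyl in place of methyl reads the same on the core of compound 1, where the second aromatic ring carries no methoxy group, as a single step on one core cannot show how far the result carries over.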